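The compounds below may be only part of what the source reports. "The series", "measured", "known", "first", "only" and "open" are said of these compounds alone.

The measured compounds:
Compound 1 `C=C1C(=O)O[C@@H]2[C@@H]1[C@H](OC(=O)C(C)C)C(=O)[C@@H](C)C[C@H](O)C[C@](C)(O)[C@H]2OC(=O)/C(C)=C\C` gives 1.38 ug/mL in a functional assay on HCT-15 cells (Homo sapiens) for cytotoxicity, read by sulforhodamine B assay; a higher number here means that more compound is needed for the effect, a lower number that less compound is needed.
Compound 2 `C=C1C(=O)O[C@@H]2[C@@H]1[C@H](OC(=O)C(C)C)C(=O)[C@@H](C)C[C@H](O)C[C@](C)(O)[C@H]2OC(=O)C(C)C` gives 3 ug/mL in this assay.

Of these two numbers, compound 2 stands highest; its nearest neighbour is compound 1, and the two are linked by a 2.2-fold higher number from compound 1 to compound 2 (0.34 log units; beyond the scatter). Compound 3 `C=C1C(=O)O[C@@H]2[C@@H]1[C@H](OC(=O)C(C)CC)C(=O)[C@@H](C)C[C@H](O)C[C@](C)(O)[C@H]2OC(=O)C(C)C` has not yet been measured in this assay. It differs from compound 2 by methyl in place of hydrogen on a saturated chain carbon, two bonds along the chain from a carbonyl carbon. For the measured compounds named here, the single measured step, a 2.2-fold higher number from compound 1 to compound 2 (0.34 log units; beyond the scatter), concerns a different change, isopropyl in place of 1-methylprop-1-en-1-yl on a carbonyl carbon, so no measured step bears directly on the exchange of hydrogen for methyl. The data therefore give no ground for expecting a step in this assay beyond the scatter in either direction. Compound 3 is expected to give about 2.5 ug/mL, within a range from 1.2 ug/mL to 5.5 ug/mL. That estimate corresponds to a 1.2-fold lower number from compound 2 to compound 3 (0.08 log units; within the scatter), a step expected to stay within the scatter.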

Compound 3, concentration for half-maximal effect: 2.06 ug/mL
Compound 3: middle estimate off by 1.2-fold (0.08 log units), on the high side; low and high end bracket the measured number.
By their numbers in this assay, from the lowest: compounds 1, 3 and 2 (each within the scatter of the next, the first and the last beyond it).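

In this assay, for the compounds shown here, methyl in place of hydrogen on a saturated chain carbon, two bonds along the chain from a carbonyl carbon, turns isopropylcarbonyl into (sec-butyl)carbonyl and gives (a 1.5-fold lower number from compound 2 to compound 3 (0.16 log units; within the scatter)), so at this place the added methyl brings no step that stands clear of the scatter. Going by these compounds alone, this is the first reading of this place, since the earlier step (a 2.2-fold higher number from compound 1 to compound 2 (0.34 log units; beyond the scatter)) concerned a change elsewhere on the shared core. No measurement shown offers an explanation for this result.

From the compounds shown here alone, it remains open whether a longer chain, a hydroxyl or an amine at this carbon would also stay within the scatter. Also open, going by these compounds, is whether the same methyl would read alike on the core of compound 1, which carries the 1-methylprop-1-en-1-yl group.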